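Sulfonate aryl ester swap on a second urea core

The compounds below may be only part of what the source reports. "The series", "measured", "known", "first", "only" and "open" are said of these compounds alone.

Compound 1 `CCc1ccccc1OS(=O)(=O)c1ccc(NC(=O)NCCCCl)cc1` and compound 2 `O=C(NCCCCl)Nc1ccc(S(=O)(=O)Oc2ccc(O)cc2)cc1` share one core, and compound 3 `CCNC(=O)Nc1cccc(S(=O)(=O)Oc2ccccc2CC)c1` with compound 4 `CCNC(=O)Nc1cccc(S(=O)(=O)Oc2ccc(O)cc2)c1` another; how the two cores differ is not broken down here. In a functional assay on MCF7 cells (Homo sapiens) for cytotoxicity, read by sulforhodamine B assay, with a stated time of 48 h (a lower number here means a stronger inhibitor, a higher number a weaker inhibitor), compound 1 gives 15000 nM and compound 2 gives 51000 nM, and compound 3 gives 31000 nM in this assay. The change from compound 1 to compound 2, (4-hydroxyphenyl in place of 2-ethylphenyl on an oxygen), brought a 3.4-fold higher number from compound 1 to compound 2 (0.53 log units; beyond the scatter). The same change, (4-hydroxyphenyl in place of 2-ethylphenyl on an oxygen), leads from compound 3 to compound 4, this change occurring twice among the compounds shown. Among the measured compounds shown here, compound 4 is expected to give 95000 nM in this assay, estimated between 35000 nM and 250000 nM, because the single earlier instance of this change gave a 3.4-fold higher number from compound 1 to compound 2 (0.53 log units; beyond the scatter). That expectation means an estimated step of a 3.1-fold higher number from compound 3 to compound 4 (0.49 log units; beyond the scatter), resting on one prior step only.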

Compound 4, half-maximal inhibitory concentration: 64000 nM
For compound 4 the middle estimate is 1.5-fold (0.17 log units) above the measured one; the range from low to high includes it.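

Replacing 2-ethylphenyl with 4-hydroxyphenyl on the oxygen bound to the sulfonyl sulfur gave, in this assay, a 2.1-fold higher number from compound 3 to compound 4 (0.31 log units; beyond the scatter). Set beside the earlier step, the change carried over from one core to the other in direction and, within the scatter, in size: the same change on two cores in this assay, a 3.4-fold higher number (0.53 log units; beyond the scatter) from compound 1 to compound 2 and a 2.1-fold higher number (0.31 log units; beyond the scatter) from compound 3 to compound 4, 1.6-fold (0.22 log units) apart, within the scatter of two such steps

This rests on two pairs of compounds in a single cell assay; it shows that the change behaved alike on these two cores, not that it would do so on any other core, and it does not show what in the change produces the step.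

The compounds shown leave open whether a phenyl bearing an amine or a carboxylic acid on that oxygen would follow the same course. They also leave open whether a core with a longer chain on the urea would keep this step.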